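Ethynyl to iodo, starting from an assay limit

A few compounds are considered here, and "the series" means these few. Any claim that something is new, unique, unknown or untested is made for them only; others in the source may bear on it.

In an ADME assay on MRC5 cells (Homo sapiens), read by MTT assay, with a stated time of 72 h (a lower number here means a stronger inhibitor, a higher number a weaker inhibitor), compound 1 `Cc1nc(N)c2c(-c3ccco3)cn([C@@H]3O[C@H](CO)[C@@H](O)[C@H]3O)c2n1` gives only a limit, > 100000 nM. Compound 2 `Cc1nc(N)c2c(-c3ccoc3)cn([C@@H]3O[C@H](CO)[C@@H](O)[C@H]3O)c2n1` also gives only a limit, > 100000 nM. Compound 3 `C#Cc1cn([C@@H]2O[C@H](CO)[C@@H](O)[C@H]2O)c2nc(C)nc(N)c12` likewise gives only a limit, > 100000 nM. Compound 3 therefore stands with the other two at the limit of > 100000 nM in this assay, at which 3 of the 3 values shown sit. Compound 4 `Cc1nc(N)c2c(I)cn([C@@H]3O[C@H](CO)[C@@H](O)[C@H]3O)c2n1` differs from compound 3 in one place: iodo in place of ethynyl on an aromatic carbon. The closest swaps on that aromatic carbon are a step that the two limits leave unreadable from compound 1 to compound 3, a step that the two limits leave unreadable from compound 2 to compound 3 and a step that the two limits leave unreadable from compound 1 to compound 2. None of these has a readable size, so the expectation is for no step beyond the scatter, held with caution. The expected change is an at least 1.2-fold lower number from compound 3 to compound 4 (0.09 log units; that floor lies within the scatter). Compound 4 is estimated at 80000 nM, with an expected range of 20000 nM to 100000 nM.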

Compound 4, half-maximal inhibitory concentration: 85800 nM
Estimate against measurement, compound 4: 1.1-fold (0.03 log units) below; measured number inside the range.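

Compound 4, with iodo on this aromatic carbon, is the only compound shown that gives a number in this assay rather than a limit: the limit of > 100000 nM in this assay, at which 3 of the 4 values shown sit.

That gives readable steps, an at least 1.1-fold lower number from compound 3 to compound 4 (0.06 log units; that floor lies within the scatter), an at least 1.1-fold lower number from compound 2 to compound 4 (0.06 log units; that floor lies within the scatter) and an at least 1.1-fold lower number from compound 1 to compound 4 (0.06 log units; that floor lies within the scatter). Each is only a floor, so the swap to iodo is not shown to matter beyond the scatter.

The steps among compound 1, compound 2 and compound 3 cannot be read. From the compounds shown here alone, how an amine or a carboxylic acid on this aromatic carbon would read in this assay also stays open.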